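Methoxy for methylsulfonyl on the aryl thiophene series

The compounds below may be only part of what the source reports. "The series", "measured", "known", "first", "only" and "open" are said of these compounds alone.

compound 1 `C/C(=C\c1cc(C2=CCCCC2)co1)C(N)=O` — > 50000 nM
compound 2 `C/C(=C\c1nc(-c2ccccc2)cs1)C(N)=O` — 3780 nM
compound 3 `C/C(=C\c1cc(-c2ccc(S(C)(=O)=O)cc2)cs1)C(N)=O` — > 50000 nM

In a functional assay on HO8910 cells (Homo sapiens) for cytotoxicity, read by CCK-8 assay, with a stated time of 24 h (on this read-out higher numbers stand for weaker inhibition and lower numbers for stronger inhibition), compound 3 gives > 50000 nM, which is a limit of the assay and not a number. Compound 1 also sits at a limit, > 50000 nM, in this assay. Within the data shown here, compound 2 gives 3780 nM in this assay, the only value of the three that is a number. Compound 3 therefore stands at the weak end of what is shown, because the limit of > 50000 nM in this assay, at which 2 of the 3 values shown sit, holds for it and for compound 1 alike.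

Compound 4 `COc1ccc(-c2csc(/C=C(\C)C(N)=O)c2)cc1` is not yet measured. It differs from compound 3 by methoxy in place of methylsulfonyl on an aromatic carbon. Among the measured compounds shown here, no step between measured compounds is available to size this change, and a step that starts at a limit cannot be read as a number. The expected step from compound 3 to compound 4, an at least 2.5-fold lower number from compound 3 to compound 4 (0.39 log units; beyond the scatter), is towards stronger inhibition, but with little confidence and with a real chance that compound 4 again sits at a limit. For compound 4 the estimate in this assay is 20000 nM, with a range from 4000 nM to 50000 nM.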

Compound 4, half-maximal inhibitory concentration: > 50000 nM
Compound 4 was reported as a limit (the forecaster's own chance of this, stated with the estimate: 45%); middle value at least 2.5-fold (0.39 log units) from the limit.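

In this assay compound 4 gives > 50000 nM, which is a limit of the assay and not a number. Among these compounds, compound 3 also sits at a limit, so no step between compound 3 and compound 4 can be read. As far as these compounds go, whether methoxy in place of methylsulfonyl changes inhibition at all remains open.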